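The source may hold more compounds than are shown below. What is called first, only, known or untested is meant among the compounds shown, and "the series" means these compounds.

Measured compounds in a functional assay on A549 cells (Homo sapiens) for inhibition; on this read-out higher numbers stand for weaker inhibition and lower numbers for stronger inhibition:
compound 1 `O=C1C=CC(OCC(F)(F)F)N1c1ccc(C(F)(F)F)cc1` gives 8390 nM
compound 2 `O=C1C=CC(OCC(F)(F)F)N1c1cc(F)cc(F)c1` gives 5000 nM

Of these two, compound 1 has the higher number in this assay, yet its gap to compound 2 lies within the usual scatter, so neither can be called weaker or stronger. Compound 3 `CCc1ccc(N2C(=O)C=CC2OCC(F)(F)F)cc1` has not yet been measured in this assay. It differs from compound 1 by ethyl in place of trifluoromethyl on an aromatic carbon. For the measured compounds named here, no measured pair covers this change, so its size and direction are unknown. The expected step from compound 1 to compound 3 is a 1.2-fold lower number from compound 1 to compound 3 (0.08 log units; within the scatter), none beyond the scatter. Compound 3 is therefore estimated at 7000 nM, with a range from 2500 nM to 20000 nM.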

Compound 3, half-maximal inhibitory concentration: 8090 nM
Compound 3: middle estimate off by 1.2-fold (0.06 log units), on the low side, within the range that was stated.
By their numbers in this assay, from the lowest: compounds 2, 3 and 1 (each within the scatter of the next).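

In this assay, ethyl in place of trifluoromethyl on the aromatic carbon para to a large group gives a 1.0-fold lower number from compound 1 to compound 3 (0.02 log units; within the scatter), the first step read at this position, and it leaves the two compounds indistinguishable. On the core of compound 1, then, these two groups, with their differing heavy-atom counts, read alike. Nothing measured here bears on why they do.

Going by these compounds, whether an amine, a carboxylic acid or a longer alkyl chain at this position would read the same remains open. So does whether a step beyond the scatter can be found here at all.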